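The source may hold more compounds than are shown below. What is called first, only, known or untested is meant among the compounds shown, and "the series" means these compounds.

Measured in a functional assay on HepG2 cells (Homo sapiens) for cytotoxicity, read by MTT assay, with a stated time of 48 h; a lower number here means a stronger inhibitor, a higher number a weaker inhibitor:
Compound 1 `Cc1ccc2[nH]c(=O)c(-c3nc4ccccc4[nH]3)cc2c1` gives > 100000 nM, which is a limit of the assay.
Compound 2 `Cc1ccc2[nH]c(=O)c(-c3nc4cc(Cl)ccc4[nH]3)cc2c1` gives 26600 nM.
Compound 3 `Cc1cc2nc(-c3cc4ccccc4[nH]c3=O)[nH]c2cc1C` gives > 100000 nM, again a limit of the assay.

Among the compounds with values here, compound 2 therefore holds the only actual number; the other two values sit at the limit of > 100000 nM in this assay, at which 2 of the 3 values shown sit. Compound 4 `Cc1ccc2[nH]c(=O)c(-c3nc4cc([N+](=O)[O-])ccc4[nH]3)cc2c1` differs from compound 2 by nitro in place of chloro on an aromatic carbon. Within the data shown here, the single measured step touching this position, an at least 3.7-fold lower number from compound 1 to compound 2 (0.57 log units; beyond the scatter), shows that placing a group there can move the number in this assay. Among the measured compounds shown here, exchanging one group for another at the same place has no measured precedent here, so the direction is open, and a change no larger than that earlier step, or none beyond the scatter, seems the reasonable expectation. Compound 4 is expected to give 30000 nM (range 8000 nM to 100000 nM), which means a 1.1-fold higher number from compound 2 to compound 4 (0.05 log units; within the scatter).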

Compound 4, half-maximal inhibitory concentration: > 100000 nM
Compound 4: only a limit was reported (the forecaster's own chance of this, stated with the estimate: 25%); at least 3.3-fold (0.52 log units) between middle value and limit.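

Nitro in place of chloro gives an at least 3.7-fold higher number from compound 2 to compound 4 (0.57 log units; beyond the scatter) on this aromatic carbon, so the exchange of one group for another here does change the result. The lower number seen with chloro therefore does not follow from placing just any group at this position. The step from compound 1 to compound 4 cannot be read, because both values are limits: the limit of > 100000 nM in this assay, at which 3 of the 4 values shown sit.

As far as these compounds go, whether fluoro, a methoxy group or an amine at this position would give a number like that of compound 2 stays open.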